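Benzyl Carbamate Swap Repeated on a Second Core

This account rests on a few compounds, and the source may have more. Where it says the series, first, only, none or still open, it means among the compounds named here.

Measured compounds:
compound 1, `CC(C)COC(=O)N1CCC(Oc2cc(Oc3ccc(/C=C4\SC(=O)NC4=O)cc3)ncn2)CC1`, 745 nM
compound 2, `O=C1NC(=O)/C(=C/c2ccc(Oc3cc(OC4CCN(C(=O)OCc5ccccc5)CC4)ncn3)cc2)S1`, 107 nM
compound 3, `CC(C)COC(=O)N1CCC(Oc2cc(Oc3cccc(/C=C4\SC(=O)NC4=O)c3)ncn2)CC1`, 720 nM

All three were tested in a functional assay on CHO-K1 cells for agonist activity at Glucose-dependent insulinotropic receptor (Homo sapiens), read by cAMP accumulation and immunoassay, with a stated time of 1 h; on this read-out higher numbers stand for an effect only at larger amounts of compound and lower numbers for an effect already at smaller amounts. Compound 1 and compound 2 share one core and differ in one place, namely (phenyl in place of isopropyl on a saturated chain carbon bound to an oxygen next to a carbonyl group). That change gave a 7.0-fold lower number from compound 1 to compound 2 (0.84 log units; beyond the scatter), a step clearly larger than the usual scatter of repeated measurements.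

Compound 3, `CC(C)COC(=O)N1CCC(Oc2cc(Oc3cccc(/C=C4\SC(=O)NC4=O)c3)ncn2)CC1`, is built from the same atoms as compound 1, joined differently; how the two cores differ is not broken down here. In this assay compound 3 gives 720 nM, a number that sits within the scatter of the value of compound 1, so no order between the two can be claimed.

Compound 4, `O=C1NC(=O)/C(=C/c2cccc(Oc3cc(OC4CCN(C(=O)OCc5ccccc5)CC4)ncn3)c2)S1`, has not yet been measured. It stands to compound 3 as compound 2 stands to compound 1: the difference is phenyl in place of isopropyl on a saturated chain carbon bound to an oxygen next to a carbonyl group, and the place is described in exactly the same words for both pairs, so this is the same change made a second time. For the measured compounds named here, the only guide to its size is the single step from compound 1 to compound 2, and two cores differing in an unbroken-down way leave room for the step to come out differently.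

Because the earlier change gave a 7.0-fold lower number from compound 1 to compound 2 (0.84 log units; beyond the scatter) and compound 3 starts from a value close to that of compound 1, compound 4 is expected to show a step of a 6.5-fold lower number from compound 3 to compound 4 (0.82 log units; beyond the scatter), giving an estimated value near 110 nM, likely between 40 nM and 320 nM.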

Compound 4, half-maximal effective concentration: 153 nM
Compound 4: middle estimate off by 1.4-fold (0.14 log units), on the low side; the range from low to high includes it.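

In this assay, replacing isopropyl with phenyl, which turns the isobutoxycarbonyl group into benzyloxycarbonyl, gave a 4.7-fold lower number from compound 3 to compound 4 (0.67 log units; beyond the scatter) on the second core. Set beside the earlier step, this shows that the change carried over from one core to the other, pointing the same way and with no difference in size that can be told apart from ordinary measurement noise: the same change on two cores in this assay, a 7.0-fold lower number (0.84 log units; beyond the scatter) from compound 1 to compound 2 and a 4.7-fold lower number (0.67 log units; beyond the scatter) from compound 3 to compound 4, 1.5-fold (0.17 log units) apart, within the scatter of two such steps. For the compounds shown here, this rests on only two cores, built from the same atoms joined differently, and it does not show that the change would behave alike on a core of another kind, nor does it explain why the number falls on either core.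

The compounds shown carry only isobutyl and benzyl at this place, which leaves open how a longer straight chain, a cyclohexylmethyl group or a benzyl group with a fluorine on its phenyl ring would read out in this assay. On these data alone, it also remains open whether the step would survive if the carbamate linking this group to the rest of the molecule gave way to an amide or a urea.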